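Dihydroxyphenyl in place of chlorophenyl on the compound 2 core

A few compounds are considered here, and "the series" means these few. Any claim that something is new, unique, unknown or untested is made for them only; others in the source may bear on it.

Of the compounds shown here, three so far have numbers in a functional assay on microsomes for inhibition, with a stated time of 1 h; on this read-out higher numbers stand for weaker inhibition and lower numbers for stronger inhibition. Compound 1 `Cn1c(NN)nc(-c2cccc(O)c2O)c(C#N)c1=O` gives 31 ug/mL. Compound 2 `CCOC(=O)c1cnn(-c2nc(-c3ccc(Cl)cc3)c(C#N)c(=O)n2C)c1N` gives 88 ug/mL, the second highest of the three numbers; compound 3 `CSc1nc(-c2ccc(N(C)C)cc2)c(C#N)c(=O)n1C` gives 98 ug/mL, within the scatter of compound 2, whereas compound 1 lies beyond the scatter at the lower end. Compound 4 `CCOC(=O)c1cnn(-c2nc(-c3cccc(O)c3O)c(C#N)c(=O)n2C)c1N` is still to be measured in this assay. Compound 4 differs from compound 2 in one place: 2,3-dihydroxyphenyl in place of 4-chlorophenyl on an aromatic carbon. Among the compounds with values here, no measured pair shares exactly this change, so the expectation rests only on compound 1, which carries the same 2,3-dihydroxyphenyl on a different core and gives 31 ug/mL. The estimate for compound 4 means an expected step of a 2.0-fold lower number from compound 2 to compound 4 (0.29 log units; within the scatter). Compound 4 is estimated at 45 ug/mL, within 20 ug/mL to 100 ug/mL.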

Compound 4, half-maximal inhibitory concentration: 49 ug/mL
Compound 4: middle estimate off by 1.1-fold (0.04 log units), on the low side; the measured number falls inside the stated range.
By their numbers in this assay, from the lowest: compounds 1, 4, 2 and 3 (each within the scatter of the next, the first and the last beyond it).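

In this assay, within the data shown here, the first matched pair at this position gives a 1.8-fold lower number from compound 2 to compound 4 (0.25 log units; within the scatter), so replacing 4-chlorophenyl with 2,3-dihydroxyphenyl does not resolve the two compounds. On the aromatic carbon ortho to a cyano group, the hydroxyl groups and the loss of chlorine therefore leave the number within the scatter. Nothing available explains this step. Still open, going by these compounds, is whether a phenyl carrying a single hydroxyl, a methoxy group or an amine in place of 4-chlorophenyl would give a step beyond the scatter. On these data alone, a carboxylic acid on that phenyl is equally open.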